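Ester chain extension on the shared core

This account rests on a few compounds, and the source may have more. Where it says the series, first, only, none or still open, it means among the compounds named here.

Measured in a functional assay on NALM-6 cells (Homo sapiens) for cytotoxicity, with a stated time of 72 h; a lower number here means that less compound is needed, a higher number that more compound is needed for the effect:
- compound 1 `C=C[C@@](C)(/C=C/c1ccc(O)cc1)CC/C=C(\C)C=O`: 12600 nM
- compound 2 `C=C[C@@](C)(/C=C/c1ccc(O)cc1)CC/C=C(\C)C(=O)OCC`: > 43400 nM

Compound 2 stands at > 43400 nM, which is a limit and not a number. Compound 3 `C=C[C@@](C)(/C=C/c1ccc(O)cc1)CC/C=C(C)/C=C/C(=O)OCC` is the next structure, with one change: 2-(ethoxycarbonyl)ethenyl in place of ethoxycarbonyl on a double-bonded chain carbon bound to a double-bonded chain carbon and a saturated chain carbon. Going by the values given here, the only measured step is an at least 3.4-fold higher number from compound 1 to compound 2 (0.53 log units; beyond the scatter), with ethoxy in place of hydrogen on a carbonyl carbon. The ester reached in that step is kept in the new structure, so no return toward the lower number is expected. The expected change in this assay is a step that the limit leaves unreadable from compound 2 to compound 3, which would stay within the scatter. Compound 3 is estimated at 45000 nM, with an expected range of 20000 nM to 90000 nM.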

Compound 3, half-maximal effective concentration: 815 nM
Estimate against measurement, compound 3: 55-fold (1.74 log units) above; the measured number lies below the stated range.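

In this assay, an ester on the double-bonded chain carbon is compatible with a low number when 2-(ethoxycarbonyl)ethenyl replaces ethoxycarbonyl, giving an at least 53-fold lower number from compound 2 to compound 3 (1.72 log units; beyond the scatter). Compound 2 carries a limit and not a number: the limit of > 43400 nM in this assay, at which 1 of the 3 values shown sits. The same group in place of formyl gives a 15-fold lower number from compound 1 to compound 3 (1.19 log units; beyond the scatter), so the ester alone does not fix a high number at this position.

The compounds shown do not separate the contribution of the ethenyl link from that of the ester end. From the compounds shown here alone, a carboxylic acid in place of the ethyl ester, or a saturated link in place of the ethenyl, remains open.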